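The source may hold more compounds than are shown below. What is called first, only, known or untested is meant among the compounds shown, and "the series" means these compounds.

In a functional assay on A-431 cells (Homo sapiens) for antiproliferative activity, read by MTT assay, with a stated time of 72 h (on this read-out higher numbers stand for weaker inhibition and lower numbers for stronger inhibition), compound 1 (`C=CC(=O)Nc1cc2c(Nc3ccc(OCc4cccc(F)c4)c(Cl)c3)ncnc2cc1OCc1cn(CCCCC(=O)NO)nn1`) gives 18800 nM, the higher of the two numbers available and so the weaker inhibition. Going by the values given here, the only other measured compound, compound 2 (`CN(C)C/C=C/C(=O)Nc1cc2ncnc(Nc3ccc(F)c(Cl)c3)c2cc1O[C@@H]1CCOC1`), gives 590 nM, a number lower than that of compound 1 by more than the scatter. Compound 3 (`C=CC(=O)Nc1cc2c(Nc3ccc(OCc4cccc(F)c4)c(Cl)c3)ncnc2cc1OCc1cn(CCC(=O)NO)nn1`) keeps the core of compound 1 and differs in one place, where hydroxycarbamoyl stands in place of 2-(hydroxycarbamoyl)ethyl on a saturated chain carbon, two bonds along the chain from an aromatic nitrogen: hydroxycarbamoyl in place of 2-(hydroxycarbamoyl)ethyl on a saturated chain carbon, two bonds along the chain from an aromatic nitrogen. Cut one bond further out, the same difference reads 4-(hydroxycarbamoyl)butyl to 2-(hydroxycarbamoyl)ethyl. Among the compounds with values here, no measured pair shows what a change at this place does, so the expectation rests mainly on the starting point of compound 1 at 18800 nM. No step beyond the scatter is expected in this assay, with only a slight leaning toward a lower number, and the estimated change is a 1.4-fold lower number from compound 1 to compound 3 (0.16 log units; within the scatter). For compound 3 the expected value is 13000 nM, with an estimated range of 4000 nM to 40000 nM.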

Compound 3, half-maximal inhibitory concentration: 16300 nM
Beside the measured number, compound 3's estimate is 1.3-fold (0.10 log units) below it, within the range that was stated.
By their numbers in this assay, from the lowest: compound 2; then compounds 3 and 1 (each within the scatter of the next).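

Going by these compounds alone, until now no measured pair spoke to this place, on a saturated chain carbon, two bonds along the chain from an aromatic nitrogen. Compound 3 supplies the first: hydroxycarbamoyl in place of 2-(hydroxycarbamoyl)ethyl, which read one bond further out is 4-(hydroxycarbamoyl)butyl to 2-(hydroxycarbamoyl)ethyl, gives a 1.2-fold lower number from compound 1 to compound 3 (0.06 log units; within the scatter) in this assay and so leaves the read-out without a step that can be told from repeat measurements, with the shared core and the hydroxycarbamoyl end group kept and only the chain differing. The compounds shown offer no measurement that explains this result.

The compounds shown leave open whether a carboxylic acid or an amine in place of the hydroxycarbamoyl at the end of this chain, or a chain longer than 4-(hydroxycarbamoyl)butyl, would also stay within the scatter of compound 1. They also leave open whether this one pair, seen on a single cell line, would read the same way on other cells or in a test on an isolated enzyme.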